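The compounds below may be only part of what the source reports. "The series", "measured", "known", "first", "only" and "open" are said of these compounds alone.

Measured compounds in this series:
compound 1 `Cc1cc(/C=C/C#N)cc(C)c1Oc1ccnc(NCCn2ccc(=O)[nH]c2=O)n1`, compound 2 `Cc1cc(C)c(Oc2cc(NCCn3ccc(=O)[nH]c3=O)nc(Cl)n2)c(C)c1`, compound 3 `Cc1cc(/C=C/C#N)cc(C)c1Oc1cc(Cl)nc(NCCn2ccc(=O)[nH]c2=O)n1`.

In an ADME assay on MT4 cells (Homo sapiens) for cytotoxicity, read by MTT assay, with a stated time of 5 days (a lower number here means that less compound is tolerated, a higher number that more compound is tolerated), compound 1 gives > 309000 nM, which is a limit of the assay rather than a number. Compound 3 gives > 284000 nM in this assay, also a limit and not a number. Compound 2 gives 76400 nM in this assay. Among the compounds with values here, compound 1 therefore stands at one of the two limits seen here, (the limit of > 309000 nM in this assay, at which 1 of the 3 values shown sits), while compound 3 sits at the limit of > 284000 nM in this assay, at which 1 of the 3 values shown sits; the only measured step, a step that the two limits leave unreadable from compound 1 to compound 3, is unreadable because both ends are limits.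

Compound 4 `Cc1cc(C)c(Oc2ccnc(NCCn3ccc(=O)[nH]c3=O)n2)c(C)c1` is not yet measured. It differs from compound 1 by methyl in place of 2-cyanoethenyl on an aromatic carbon. Within the data shown here, no measured step covers this change directly. The pair compound 3 and compound 2 shows the same exchange of groups, with a limit for one and a number for the other, so the change may bring the value down into the readable range. The step from compound 1 to compound 4 is estimated at an at least 2.5-fold lower number from compound 1 to compound 4 (0.41 log units; beyond the scatter) in this assay. Compound 4 is expected to give about 120000 nM in this assay, estimated between 40000 nM and 400000 nM.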

Compound 4, half-maximal cytotoxic concentration: 272000 nM
The estimate for compound 4 lay 2.3-fold (0.36 log units) below the measured number, within the range that was stated.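

In this assay compound 4 gives 272000 nM, a number rather than a limit, so methyl at this position on the six-membered aromatic ring of carbon only has a readable value. Replacing 2-cyanoethenyl with methyl gives an at least 1.1-fold lower number from compound 1 to compound 4 (0.05 log units; that floor lies within the scatter), so a lowering beyond the scatter is not shown for this change, though it is also not excluded. The step remains only a floor because compound 1 stands at a limit of the assay: the limit of > 309000 nM in this assay, at which 1 of the 4 values shown sits.

Going by these compounds, the true value of compound 1, and with it the real size of the step, stays open. Also open, on these data alone, is how an aminomethyl group, a carboxylic acid or a longer chain carrying a nitrile at this position would compare with methyl and 2-cyanoethenyl.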